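Compound 3: Swapping 4-Aminocyclohexyl for 1-Phenylethyl

The source may report more compounds than this note shows. Statements on the series, on what has been measured and on what is new or still open speak of the compounds shown alone.

Compound 1 `CN(C)CCCNc1c(C(=O)NCc2ccc(F)cc2)nc(Br)c2cccnc12` reaches only a limit in a functional assay on HCT-116 cells (Homo sapiens) for cytotoxicity, read by MTT assay, with a stated time of 72 h (a higher number here means a weaker inhibitor, a lower number a stronger inhibitor), at > 10000 nM. Going by the values given here, compound 2 `N[C@H]1CC[C@H](Nc2c(C(=O)NCc3ccc(F)cc3)nc(Br)c3cccnc23)CC1` gives 4000 nM, the only actual number so far. Compound 3 `C[C@H](Nc1c(C(=O)NCc2ccc(F)cc2)nc(Br)c2cccnc12)c1ccccc1` carries 1-phenylethyl in place of 4-aminocyclohexyl on a nitrogen on an aromatic ring. Among the compounds with values here, the sole measured guide is a change at this same nitrogen, an at least 2.5-fold lower number from compound 1 to compound 2 (0.39 log units; beyond the scatter), and it shows that this substituent can move the result. A modest step toward a weaker number is therefore expected, a 2.3-fold higher number from compound 2 to compound 3 (0.35 log units; beyond the scatter). The expected value for compound 3 is 9000 nM, with an estimated range of 3000 nM to 25000 nM.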

Compound 3, half-maximal inhibitory concentration: > 20000 nM
Compound 3: a limit, no number; the forecaster's own chance of this, stated with the estimate: 45%; at least 2.2-fold (0.34 log units) between middle value and limit.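

In this assay, 1-phenylethyl in place of 4-aminocyclohexyl on this nitrogen gives an at least 5.0-fold higher number from compound 2 to compound 3 (0.69 log units; beyond the scatter), so a carbon-only aromatic ring with no amine does not match the result of compound 2. Compound 3 has only a limit, not a number: the limit of > 20000 nM in this assay, at which 1 of the 3 values shown sits. Compound 1 and compound 3 both stand at limits, so the step between them cannot be read, and only compound 2 gives a number.

From the compounds shown here alone, it remains open whether the amine or the non-aromatic ring of compound 2 matters more. Plain cyclohexyl or a short chain ending in a primary amine, such as 2-aminoethyl, would separate the two.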